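From Methyl to Trifluoromethyl on the Shared Core

A few compounds are considered here, and "the series" means these few. Any claim that something is new, unique, unknown or untested is made for them only; others in the source may bear on it.

In a functional assay on MCF7 cells (Homo sapiens) for cytotoxicity, read by WST assay, with a stated time of 72 h (a lower number here means a stronger inhibitor, a higher number a weaker inhibitor), compound 1 `O=C1Nc2ccccc2C1(c1ccc(O)cc1)C1CCCCCC1` gives 247 nM. Compound 2 `Cc1cccc2c1NC(=O)C2(c1ccc(O)cc1)C1CCCCCC1` gives > 1000 nM, which is a limit of the assay and not a number. Compound 2 is therefore known only by this limit, on the weaker side of the pair.

Compound 3 `O=C1Nc2c(C(F)(F)F)cccc2C1(c1ccc(O)cc1)C1CCCCCC1` keeps the shared core and changes one group: trifluoromethyl in place of methyl on an aromatic carbon. Among the measured compounds shown here, the one measured step that bears on this change is an at least 4.0-fold higher number from compound 1 to compound 2 (0.60 log units; beyond the scatter), which lies beyond the scatter and comes from methyl in place of hydrogen on that same aromatic carbon. A single step cannot show how trifluoromethyl will behave. Still, on the strength of an at least 4.0-fold higher number from compound 1 to compound 2 (0.60 log units; beyond the scatter), compound 3 is expected to remain weak in this assay, with no clear return towards the number of compound 1.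

The expected change is small and its direction uncertain, an estimated step that the limit leaves unreadable from compound 2 to compound 3. For compound 3 the estimated value is 1200 nM, with an expected range from 350 nM to 4000 nM.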

Compound 3, half-maximal inhibitory concentration: 9.7 nM
Estimate against measurement, compound 3: 120-fold (2.09 log units) above, and the stated range ends above it.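

In this assay, the earlier pair showed only that methyl on this aromatic carbon goes with a weaker number, whereas the new result shows that the same carbon can also carry a group that goes with a much stronger one: trifluoromethyl in place of hydrogen gives a 25-fold lower number from compound 1 to compound 3 (1.41 log units; beyond the scatter). Methyl and trifluoromethyl thus move the number in opposite directions from hydrogen on the same carbon, so this position is highly sensitive to the identity of its group, and exchanging one for the other gives an at least 100-fold lower number from compound 2 to compound 3 (2.01 log units; beyond the scatter). Compound 2 is known only by a limit of the assay, not by a number, so that second step is a bound and not an exact size: the limit of > 1000 nM in this assay, at which 1 of the 3 values shown sits.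

What separates trifluoromethyl from methyl here remains open, as these three compounds come with no measured property of either group that could explain the reversal. From the compounds shown here alone, it is also open whether a chlorine atom, a nitrile or a methoxy group on this same carbon would follow trifluoromethyl or methyl, and whether trifluoromethyl would have a similar effect on another carbon of this aromatic ring.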